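The source may report more compounds than this note shows. Statements on the series, on what has been measured and on what is new or still open speak of the compounds shown alone.

The measured compounds:

compound 1, `CCO[C@H]1C[C@@H](c2coc3ccc(F)cc3c2=O)N(c2ccccc2)O1`, which in a functional assay on A549 cells (Homo sapiens) for inhibition, read by sulforhodamine B assay, with a stated time of 48 h (on this read-out lower numbers stand for stronger inhibition and higher numbers for weaker inhibition), gives 26400 nM
compound 2, `CCO[C@H]1C[C@@H](c2coc3ccc(C)cc3c2=O)N(c2ccccc2)O1`, which in this assay gives 20700 nM
compound 3, `COC(=O)[C@@]1(C)C[C@@H](c2coc3ccc(F)cc3c2=O)N(c2ccccc2)O1`, which in this assay gives 20300 nM

Compound 1 and compound 2 share one core and differ in a single place: methyl in place of fluoro on an aromatic carbon. This change gives a 1.3-fold lower number from compound 1 to compound 2 (0.11 log units; within the scatter), so the two values cannot be told apart. Compound 3 is built on another core; how the two cores differ is not broken down here. Its value in this assay lies within the usual scatter of the values of compound 1 and of compound 2, so none of the three can be called more or less potent than another.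

Compound 4, `COC(=O)[C@@]1(C)C[C@@H](c2coc3ccc(C)cc3c2=O)N(c2ccccc2)O1`, has not yet been measured. It stands to compound 3 as compound 2 stands to compound 1: methyl in place of fluoro on an aromatic carbon. The place of the change is described in the same words for both pairs, so it is the same change made on a second core. Among the measured compounds shown here, the only guide to its effect is the one measured instance, a 1.3-fold lower number from compound 1 to compound 2 (0.11 log units; within the scatter), which did not move the value beyond the scatter. On that basis compound 4 is expected to show a 1.2-fold lower number from compound 3 to compound 4 (0.08 log units; within the scatter) in this assay, because compound 2 differed so little from compound 1 in a 1.3-fold lower number from compound 1 to compound 2 (0.11 log units; within the scatter). Compound 4 is therefore estimated at 17000 nM, with a likely span from 7000 nM to 40000 nM.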

Compound 4, half-maximal inhibitory concentration: 700 nM
Estimate against measurement, compound 4: 24-fold (1.39 log units) above; measured number below the stated range.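

On the second core, methyl in place of fluoro on an aromatic carbon gave a 29-fold lower number from compound 3 to compound 4 (1.46 log units; beyond the scatter) in this assay, and the two instances of this change do not agree: the same change on two cores in this assay, a 1.3-fold lower number (0.11 log units; within the scatter) from compound 1 to compound 2 and a 29-fold lower number (1.46 log units; beyond the scatter) from compound 3 to compound 4, 23-fold (1.36 log units) apart, beyond the scatter of two such steps. Among the compounds shown here, the effect of the change therefore did not carry over from the core of compound 1 to the core of compound 3, and the small step on the first core gave no guide to the large step on the second. These two pairs do not show which feature of the cores sets the two steps apart, nor why the methyl compound stands so far from the fluoro compound on one core only, and they say nothing about how the change would behave on any third core or in any other assay.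

With only fluoro and methyl shown at this aromatic carbon, it stays open how a chlorine, a methoxy group or a longer chain such as ethyl would behave there on either core. From the compounds shown here alone, it is also open whether a carboxylic acid or an amide in place of the ester would keep the value of compound 4, 700 nM.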